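Adding a second methoxy to the sulfonate ester aryl ring

This account rests on a few compounds, and the source may have more. Where it says the series, first, only, none or still open, it means among the compounds named here.

Measured compounds:
compound 1 `COc1cccc(OS(=O)(=O)c2ccc(N3CCN(C)C3=O)cc2)c1`, 3000 nM
compound 2 `COc1ccc(OS(=O)(=O)c2ccc(N3CCN(C)C3=O)cc2)cc1OC`, 12000 nM
compound 3 `CCCN1CCN(c2ccc(S(=O)(=O)Oc3cccc(OC)c3)cc2)C1=O`, 6300 nM

All three were tested in a functional assay on MCF7 cells (Homo sapiens) for antiproliferative activity, read by sulforhodamine B assay, with a stated time of 48 h; on this read-out higher numbers stand for weaker inhibition and lower numbers for stronger inhibition. The change from compound 1 to compound 2 is methoxy in place of hydrogen on an aromatic carbon, and it gave a 4.0-fold higher number from compound 1 to compound 2 (0.60 log units; beyond the scatter). Compound 4 `CCCN1CCN(c2ccc(S(=O)(=O)Oc3cc(OC)cc(OC)c3)cc2)C1=O` has not yet been measured; it differs from compound 3 by methoxy in place of hydrogen on an aromatic carbon. Among the measured compounds shown here, this is the same kind of change as the one between compound 1 and compound 2, though the entering methoxy here sits meta to a large group and meta to a methoxy group, whereas in compound 2 it sits ortho to a methoxy group and para to a large group. The cores of the two pairs differ by ethyl in place of hydrogen on a saturated chain carbon bound to an amide-type nitrogen in a ring, which gave a 2.1-fold higher number from compound 1 to compound 3 (0.32 log units; beyond the scatter). For compound 4 in this assay a step of roughly a 3.0-fold higher number from compound 3 to compound 4 (0.48 log units; beyond the scatter) is expected, resting on the weakening seen in a 4.0-fold higher number from compound 1 to compound 2 (0.60 log units; beyond the scatter). The surroundings of the new group differ, which leaves the expected step somewhat tempered. Compound 4 is therefore estimated at 19000 nM, within 8000 nM to 45000 nM.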

Compound 4, half-maximal inhibitory concentration: 270 nM
Estimate against measurement, compound 4: 70-fold (1.85 log units) above, outside the stated range (below it).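

In this assay, the added methoxy gave a 23-fold lower number from compound 3 to compound 4 (1.37 log units; beyond the scatter), the opposite direction to the earlier step, so this change did not carry over from one core to the other: the same change on two cores in this assay, a 4.0-fold higher number (0.60 log units; beyond the scatter) from compound 1 to compound 2 and a 23-fold lower number (1.37 log units; beyond the scatter) from compound 3 to compound 4, 93-fold (1.97 log units) apart, beyond the scatter of two such steps. The effect of a methoxy on one of these cores therefore gave no reliable guide to its effect on the other. This does not show whether the chain or the place of the new methoxy accounts for the reversal, as the two pairs differ in both.

The compounds shown leave open how the methoxy pattern of compound 4 behaves with the methyl group of compound 1. They also leave open whether a butyl chain, or an amine in place of the new methoxy, would keep the stronger inhibition.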